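The compounds below may be only part of what the source reports. "The series", "measured", "known", "first", "only" and "open" are said of these compounds alone.

Measured so far in a functional assay on the whole organism (Tail, strain ICR) with Mus musculus as the target, in the tail flick test, with a stated time of 30 min, at a dose of 25 umol/kg by the oral route; on this read-out lower numbers stand for a weaker effect and higher numbers for a stronger effect at the one dose given:
compound 1 `N=C(N)NCCC[C@H](NC(=O)CN(c1nc(Cl)nc2[nH]cnc12)C1CC1)C(=O)O` — 45.4%
compound 2 `NCCCC[C@H](NC(=O)CN(c1nc(Cl)nc2[nH]cnc12)C1CC1)C(=O)O` — 31.2%

Among the measured compounds shown here, compound 2 stands lowest of the two numbers; the one measured step, a number 14.2 percentage points lower from compound 1 to compound 2 (beyond the scatter), exchanged a group of 4 heavy atoms for a group of 2 on the same chain and lowered the read-out beyond the scatter. Compound 3 `O=C(O)C[C@H](NC(=O)CN(c1nc(Cl)nc2[nH]cnc12)C1CC1)C(=O)O` is not yet measured; its change from compound 2 is carboxy in place of 3-aminopropyl on a saturated chain carbon, two bonds along the chain from an amide-type nitrogen and a carbonyl carbon. For the measured compounds named here, only that one step bears on it, and it points downward. A further modest drop, a number 11.2 percentage points lower from compound 2 to compound 3 (beyond the scatter), is expected, so compound 3 is estimated at 20%, within 8% to 34%.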

Compound 3, a percentage reported as activity, at one dose (the size of the read-out at that dose, not a potency): 19.9%
Beside the measured number, compound 3's estimate is 0.1 percentage points above it, within the range that was stated.
By their numbers in this assay, from the lowest: compound 3; then compound 2; then compound 1.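

In this assay, carboxy in place of 3-aminopropyl, on a saturated chain carbon, two bonds along the chain from an amide-type nitrogen and a carbonyl carbon, gives a number 11.3 percentage points lower from compound 2 to compound 3 (beyond the scatter). The wider exchange gives a number 25.5 percentage points lower from compound 1 to compound 3 (beyond the scatter), so a side chain without nitrogen now stands lowest of the three, whereas the earlier pair compared only nitrogen-bearing chains. No evidence on hand accounts for this fall. Going by these compounds, what a longer carboxylic acid chain, such as 2-carboxyethyl, or a plain methyl would give at this carbon remains open.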